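This account rests on a few compounds, and the source may have more. Where it says the series, first, only, none or still open, it means among the compounds named here.

Working notes on the benzyl-substituted nucleoside series.

Three compounds have numbers in a functional assay on CCRF-CEM cells (Homo sapiens) for antiproliferative activity, with a stated time of 72 h; a higher number here means a weaker inhibitor, a lower number a stronger inhibitor. Compound 1 `OC[C@H]1O[C@@H](n2cnc3c(NCc4ccccc4Cl)ncnc32)[C@H](O)[C@@H]1O` gives 14500 nM. Compound 2 `OC[C@H]1O[C@@H](n2cnc3c(NCc4ccccc4Br)ncnc32)[C@H](O)[C@@H]1O` gives 12300 nM. Compound 3 `OC[C@H]1O[C@@H](n2cnc3c(NCc4cccc(Br)c4)ncnc32)[C@H](O)[C@@H]1O` gives 5000 nM. Compound 2 stands second highest of the three; its nearest neighbour is compound 1, as the exchange of bromo in place of chloro on an aromatic carbon gave a 1.2-fold lower number from compound 1 to compound 2 (0.07 log units; within the scatter). For the measured compounds named here, the only step of size in the set is a 2.5-fold lower number from compound 2 to compound 3 (0.39 log units; beyond the scatter), matched by a 2.9-fold lower number from compound 1 to compound 3 (0.46 log units; beyond the scatter).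

The next compound, compound 4 `Cc1cccc(CNc2ncnc3c2ncn3[C@@H]2O[C@H](CO)[C@@H](O)[C@H]2O)c1O`, is an untested member. Its change from compound 2 is 2-hydroxy-3-methylphenyl in place of 2-bromophenyl on a saturated chain carbon bound to a nitrogen on an aromatic ring. Going by the values given here, no measured step replaces a halogen with a hydroxy and methyl pair, so only two steps bear on it: the halogen swap within the scatter and the modest change on moving the bromine. The pattern of the three compounds suggests that changes at this phenyl shift the number by little. For compound 4 the step of a 1.2-fold lower number from compound 2 to compound 4 (0.09 log units; within the scatter) is expected, with only small movement foreseen. Compound 4 is estimated at 10000 nM, within a range of 3000 nM to 35000 nM.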

Compound 4, half-maximal inhibitory concentration: 900 nM
Estimate against measurement, compound 4: 11-fold (1.05 log units) above; measured number outside the range, below it.
By their numbers in this assay, from the lowest: compound 4; then compound 3; then compounds 2 and 1 (each within the scatter of the next).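

In this assay this place on the saturated chain carbon bound to a nitrogen on an aromatic ring proves far more responsive than the halogen compounds suggested: their steps were within the scatter or modest, whereas 2-hydroxy-3-methylphenyl gives a 14-fold lower number from compound 2 to compound 4 (1.14 log units; beyond the scatter) and a 16-fold lower number from compound 1 to compound 4 (1.21 log units; beyond the scatter), both large. Compound 4 also clears the lowest halogen compound, with a 5.6-fold lower number from compound 3 to compound 4 (0.74 log units; beyond the scatter), so moving the bromine did not reach the lowest number available here. Nothing on hand accounts for the drop.

The compounds shown leave open whether the hydroxy, the methyl or the pair carries the step, as both enter together. Also open, on these data alone, is how a methoxy or an amine in place of the hydroxy would read in this assay.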